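Cyclohexyl to pentyl on a carbonyl carbon

The compounds below may be only part of what the source reports. "The series", "measured", "known", "first", "only" and "open" are said of these compounds alone.

Compound 1 `O=C(N/N=C/c1ccc([N+](=O)[O-])o1)C1CCCCC1`: > 200000 nM
Compound 2 `CCCCOc1ccc(C(=O)N/N=C/c2ccc([N+](=O)[O-])o2)cc1`: > 200000 nM

In an ADME assay on LL24 cells (Homo sapiens) for inhibition, read by MTT assay, with a stated time of 24 h (on this read-out higher numbers stand for weaker inhibition and lower numbers for stronger inhibition), compound 1 gives > 200000 nM, which is a limit of the assay and not a number. Compound 2 gives > 200000 nM, which is also a limit. The evidence so far is therefore (the limit of > 200000 nM in this assay, at which 2 of the 2 values shown sit).

Compound 3 `CCCCCC(=O)N/N=C/c1ccc([N+](=O)[O-])o1` has not yet been measured. It keeps the core of compound 1 and changes one group: pentyl in place of cyclohexyl on a carbonyl carbon. In words, this is pentyl in place of cyclohexyl on a carbonyl carbon.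

For the measured compounds named here, no measured pair shows what this swap does. Since compound 1 gives only > 200000 nM, no step beyond the usual scatter is expected in this assay, and no direction can be favoured. The expected change is a number no higher from compound 1 to compound 3 (the limit leaves the size open). Compound 3 is estimated at 200000 nM, with an expected range from 100000 nM to 400000 nM.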

Compound 3, half-maximal inhibitory concentration: 99000 nM
Compound 3: middle estimate off by 2.0-fold (0.31 log units), on the high side; the whole stated range lies above it.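

In this assay, for the compounds shown here, compound 3 gives 99000 nM, the only value shown here that is a number and not a limit. Compound 1 gives > 200000 nM, which is a limit. Pentyl in place of cyclohexyl on a carbonyl carbon therefore comes with an at least 2.0-fold lower number from compound 1 to compound 3 (0.30 log units; that floor lies within the scatter), so this position can carry a group that brings a measurable value, though the true size of the step may be larger and the limit cannot say by how much.

Going by these compounds, it stays open whether the open chain or simply the loss of the ring goes with this value, and whether a longer chain such as octyl, or a chain ending in an amine, would lower the number further. Most of the set offers no number to compare with: the limit of > 200000 nM in this assay, at which 2 of the 3 values shown sit.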